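Bromo for methyl on two related cores

The source may report more compounds than this note shows. Statements on the series, on what has been measured and on what is new or still open speak of the compounds shown alone.

Measured compounds:
Compound 1, `COC(=O)[C@@]1(C)CC[C@@H]2C3=C1CC[C@@H](C)[C@]3(C)C[C@@H]1c3cc(C)ccc3N[C@H]21`, 18000 nM
Compound 2, `COC(=O)[C@@]1(C)CC[C@@H]2C3=C1CC[C@@H](C)[C@]3(C)C[C@@H]1c3cc(Br)ccc3N[C@H]21`, 25000 nM
Compound 3, `COC(=O)[C@@]1(C)CC[C@@H]2C3=C1CC[C@@H](C)[C@]3(C)Cc1c2[nH]c2ccc(C)cc12`, 11000 nM

In a functional assay on HeLa cells (Homo sapiens) for inhibition, read by sulforhodamine B assay, with a stated time of 48 h (on this read-out lower numbers stand for stronger inhibition of growth and higher numbers for weaker inhibition of growth), compound 1 gives 18000 nM and compound 2 gives 25000 nM. The change between them, (bromo in place of methyl on an aromatic carbon), made a step of a 1.4-fold higher number from compound 1 to compound 2 (0.14 log units; within the scatter). Compound 3 gives 11000 nM in this assay; the difference between its core and the core of compound 1 is not broken down here. Compound 4, `COC(=O)[C@@]1(C)CC[C@@H]2C3=C1CC[C@@H](C)[C@]3(C)Cc1c2[nH]c2ccc(Br)cc12`, carries the same change, (bromo in place of methyl on an aromatic carbon), on the core of compound 3. Because the step of a 1.4-fold higher number from compound 1 to compound 2 (0.14 log units; within the scatter) stayed within the scatter, compound 4 is expected to sit near compound 3, with an estimated step of a 1.5-fold higher number from compound 3 to compound 4 (0.16 log units; within the scatter). The expected value of compound 4 in this assay is 16000 nM, likely between 8000 nM and 32000 nM.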

Compound 4, concentration for 50% growth inhibition: 14000 nM
The estimate for compound 4 lay 1.1-fold (0.06 log units) above the measured number; low and high end bracket the measured number.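

In this assay, bromo in place of methyl gave a step of a 1.3-fold higher number from compound 3 to compound 4 (0.10 log units; within the scatter), and the change behaved on this core as it did on the core of compound 1: the same change on two cores in this assay, a 1.4-fold higher number (0.14 log units; within the scatter) from compound 1 to compound 2 and a 1.3-fold higher number (0.10 log units; within the scatter) from compound 3 to compound 4, 1.1-fold (0.04 log units) apart, within the scatter of two such steps

This shows that the swap carries across these two cores, in that it leaves the number within the scatter on both. It does not show that a change with a larger step would carry over in the same way, and two cores in a single assay say nothing about other cores in the series.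

The compounds shown leave open how a group such as an amine, a nitrile or a carboxylic acid would read on this aromatic carbon. They also leave open what a change to the methyl ester would do on either core.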